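Swapping a Benzyl for a Phenyl on the Sulfonamide Nitrogen

A few compounds are considered here, and "the series" means these few. Any claim that something is new, unique, unknown or untested is made for them only; others in the source may bear on it.

Measured in a physicochemical assay for lipophilicity, at pH 7.4; on this read-out lower numbers stand for lower lipophilicity and higher numbers for higher lipophilicity:
- compound 1 `O=S(=O)(Nc1ccccc1C(F)(F)F)c1ccc2c(c1)C(O)CC(C1CCOCC1)O2`: 2.41
- compound 2 `CC(C)CN(Cc1ccccc1C(F)(F)F)S(=O)(=O)c1ccc2c(c1)C(O)CC(C1CCOCC1)O2`: 4.23

Of these two, compound 2 stands highest at 4.23, and the gap down to compound 1 at 2.41 lies well beyond the usual scatter. The two differ in more than one place, so their gap says nothing about any single change.

The next compound is compound 3 `CC(C)CN(c1ccccc1C(F)(F)F)S(=O)(=O)c1ccc2c(c1)C(O)CC(C1CCOCC1)O2`. Here 2-(trifluoromethyl)phenyl stands in place of 2-(trifluoromethyl)benzyl on a sulfonamide nitrogen: 2-(trifluoromethyl)phenyl in place of 2-(trifluoromethyl)benzyl on a sulfonamide nitrogen. The rest of the structure stays the same, including the saturated chain on that nitrogen.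

Going by the values given here, no measured pair shows this change alone, so the step in this assay has to be judged. Among the compounds with values here, only this one group differs from compound 2 at 4.23, so compound 3 is expected to stay much nearer to that value than to compound 1.

The expected change is a number 0.33 log units lower from compound 2 to compound 3 (beyond the scatter), a small drop near the edge of the scatter.

For compound 3 the estimated value is 3.9, with an expected range from 3.4 to 4.3.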

Compound 3, distribution coefficient: 4.14
The estimate for compound 3 lay 0.24 log units below the measured number; the range from low to high includes it.
By their numbers in this assay, from the lowest: compound 1; then compounds 3 and 2 (each within the scatter of the next).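

In this assay, 2-(trifluoromethyl)phenyl in place of 2-(trifluoromethyl)benzyl on the sulfonamide nitrogen gives a number 0.09 log units lower from compound 2 to compound 3 (within the scatter), so at this position, with isobutyl on the same nitrogen, losing the carbon that separates the aromatic ring from the nitrogen leaves the two compounds indistinguishable on this read-out. Going by these compounds alone, compound 3 also provides the first clean comparison for the other substituent on that nitrogen: isobutyl in place of hydrogen gives a number 1.73 log units higher from compound 1 to compound 3 (beyond the scatter), a large step that dwarfs the phenyl-for-benzyl swap. Nothing available here explains why one change matters so much and the other so little.

As far as these compounds go, only hydrogen and isobutyl appear as the saturated-chain position on this nitrogen, so it remains open how the read-out would respond to a longer chain or to a chain ending in a carboxylic acid. From the compounds shown here alone, whether the phenyl-for-benzyl swap would stay as small with hydrogen in place of isobutyl on the nitrogen also remains open.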